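The source may report more compounds than this note shows. Statements on the series, on what has been measured and on what is new or still open speak of the compounds shown alone.

Compound 1, `Cc1ccccc1Oc1ccc(C#N)cc1S(=O)(=O)NC(=O)NC(C)(C)C`, gives 1470 nM in a functional assay on HEK293 cells for antagonist activity at thromboxane A2 receptor (Homo sapiens), read by fluorescence and calcium flux; on this read-out lower numbers stand for stronger inhibition and higher numbers for weaker inhibition.
Compound 2, `CCCCCNC(=O)NS(=O)(=O)c1cc(C#N)ccc1Oc1ccccc1C`, gives 1780 nM in this assay.

These two compounds differ only in the group on the amide-type nitrogen, pentyl in compound 2 in place of tert-butyl in compound 1, and the step from compound 1 to compound 2 is a 1.2-fold higher number from compound 1 to compound 2 (0.08 log units; within the scatter). On the numbers shown, compound 2 therefore stands together with compound 1, the two values within the usual scatter of each other.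

Compound 3 is `CCCCCNC(=O)NS(=O)(=O)c1cc(C#N)ccc1Nc1ccccc1C`. It keeps the pentyl urea of compound 2 and changes the other end: (2-methylphenyl)amino in place of 2-methylphenoxy on an aromatic carbon. Going by the values given here, no measured step in this set touches that part of the molecule; the only measured step, from compound 1 to compound 2, concerns the substituent on the amide-type nitrogen and so does not speak to the change from compound 2 to compound 3. With nothing in the data pointing either way, the expectation for compound 3 in this assay is a step of a 1.0-fold higher number from compound 2 to compound 3 (0.00 log units; within the scatter), that is, no shift beyond the scatter, with a wide margin of uncertainty. Compound 3 is accordingly estimated at 1800 nM, in a range from 500 nM to 6500 nM.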

Compound 3, half-maximal inhibitory concentration: 7850 nM
Beside the measured number, compound 3's estimate is 4.4-fold (0.64 log units) below it; measured number outside the range, above it.
By their numbers in this assay, from the lowest: compounds 1 and 2 (each within the scatter of the next); then compound 3.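

The linking atom on this aromatic carbon, ortho to a large group and para to a cyano group, matters to the read-out: (2-methylphenyl)amino in place of 2-methylphenoxy gives a 4.4-fold higher number from compound 2 to compound 3 (0.64 log units; beyond the scatter) in this assay, which means weaker inhibition. Going by these compounds alone, this is the first step in the set beyond the scatter, whereas the change at the other end of the molecule, pentyl in place of tert-butyl on the amide-type nitrogen, gave a 1.2-fold higher number from compound 1 to compound 2 (0.08 log units; within the scatter). The entering group has the same number of heavy atoms as the leaving one and adds a hydrogen-bond donor, but nothing available here ties the loss of inhibition to that difference or to any other feature of the change.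

The compounds shown leave open how a thioether or a methylene link at this carbon would stand, and whether a (2-methylphenyl)(methyl)amino group, which keeps the nitrogen without its hydrogen, would follow compound 2 or compound 3. They also leave open whether the same change would give a step of similar size on the tert-butyl urea of compound 1.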